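The source may report more compounds than this note shows. Statements on the series, on what has been measured and on what is new or still open speak of the compounds shown alone.

In a functional assay on cells (Neutrophil, Homo sapiens) for inhibition, with a stated time of 10 min (on this read-out lower numbers stand for stronger inhibition and higher numbers for weaker inhibition), compound 3 `NC(=O)c1cnn2c1N(C(=O)Nc1ccccc1F)C(c1ccccc1)C2` gives 6.2 nM and compound 1 `CCOC(=O)c1cnn2c1N(C(=O)Nc1ccccc1F)C(c1ccccc1)C2` gives 7.5 nM, so the two stand level within the scatter. For compound 2 `CCOC(=O)c1cnn2c1N(C(=O)Nc1ccc(F)cc1)C(c1ccccc1)C2` the assay reports only a limit, > 1000 nM. The change leading to compound 4 `NC(=O)c1cnn2c1N(C(=O)Nc1ccc(F)cc1)C(c1ccccc1)C2` is 4-fluorophenyl in place of 2-fluorophenyl on an amide-type nitrogen. The same exchange of fluorophenyl groups gave an at least 130-fold higher number from compound 1 to compound 2 (2.12 log units; beyond the scatter), a large step beyond the scatter. Amino in place of ethoxy on a carbonyl carbon gave only a 1.2-fold lower number from compound 1 to compound 3 (0.08 log units; within the scatter), so the earlier exchange is expected to carry over to the amino-bearing pair. A large rise in the number is therefore expected, with an estimated step of a 240-fold higher number from compound 3 to compound 4 (2.38 log units; beyond the scatter). For compound 4 the expected value is 1500 nM, with an estimated range of 300 nM to 6000 nM.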

Compound 4, half-maximal inhibitory concentration: 484 nM
Compound 4: the middle estimate sits 3.1-fold (0.49 log units) above what was measured; measured number inside the range.
By their numbers in this assay, from the lowest: compounds 3 and 1 (each within the scatter of the next); then compound 4. At a limit, above all of these: compound 2.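

In this assay, the exchange of 2-fluorophenyl for 4-fluorophenyl on the amide-type nitrogen now has a measured size, a 78-fold higher number from compound 3 to compound 4 (1.89 log units; beyond the scatter). Compound 2 gives only a limit, > 1000 nM. Amino in place of ethoxy on a carbonyl carbon, level on the 2-fluorophenyl pair, gives an at least 2.0-fold lower number from compound 2 to compound 4 (0.31 log units; beyond the scatter), so this change is not silent on every core, although the comparison remains limited: the same change on two cores in this assay, a 1.2-fold lower number (0.08 log units; within the scatter) from compound 1 to compound 3 and an at least 2.0-fold lower number (0.31 log units; beyond the scatter) from compound 2 to compound 4; the limit leaves it open whether they differ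

The compounds shown leave open how plain phenyl or 2-chlorophenyl would read on that nitrogen. They also leave open how a carboxylic acid would read in place of the ethyl ester or the amide on the shared core.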